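Pyridin-4-yl in place of 2-methoxyphenyl on a shared core

This account rests on a few compounds, and the source may have more. Where it says the series, first, only, none or still open, it means among the compounds named here.

Compound 1 `COc1ccccc1-c1nnc(-c2sc(-c3cccnc3)nc2C)o1` was examined in an ADME assay on HeLa cells (Homo sapiens) for cytotoxicity, read by MTT assay; on this read-out lower numbers stand for higher toxicity in this test and higher numbers for lower toxicity in this test. In this assay compound 1 gives > 100 ug/mL, which is a limit of the assay and not a number. Compound 2 `Cc1ccc(-c2nnc(-c3sc(-c4cccnc4)nc3C)o2)cc1` carries 4-methylphenyl in place of 2-methoxyphenyl on an aromatic carbon. In this assay compound 2 gives > 100 ug/mL, again only a limit. The step that the two limits leave unreadable from compound 1 to compound 2 cannot be read because of the limit of > 100 ug/mL in this assay, at which 2 of the 2 values shown sit. Compound 1 therefore stands at the limit, with no measured number to place it above or below any other compound. Compound 3 `Cc1nc(-c2cccnc2)sc1-c1nnc(-c2ccncc2)o1` differs from compound 1 as follows: pyridin-4-yl in place of 2-methoxyphenyl on an aromatic carbon. Among the compounds with values here, the one measured step concerns a different change and is itself unreadable, so it gives no direction; the expectation rests on both known values sitting at the limit. Compound 3 is expected to give 150 ug/mL, between 60 ug/mL and 400 ug/mL, and the step that the limit leaves unreadable from compound 1 to compound 3 is expected to stay within the scatter.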

Compound 3, half-maximal cytotoxic concentration: > 100 ug/mL
Compound 3: a limit, no number; the forecaster's own chance of this, stated with the estimate: 80%; the middle value does not contradict the limit.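

No step among compound 1, compound 2 and compound 3 can be read, because each gives a limit of the assay and not a number: the limit of > 100 ug/mL in this assay, at which 3 of the 3 values shown sit.

The compounds shown leave open how these three compare in this assay, and whether exchanging 2-methoxyphenyl, 4-methylphenyl and pyridin-4-yl changes the read-out at all.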